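The compounds below may be only part of what the source reports. "The series", "measured", "known", "first", "only" and "open" are said of these compounds alone.

Three sulfoxides sharing one core have been measured in an assay on HEK293 cells for inhibition of sodium-dependent dopamine transporter (Homo sapiens), read by scintillation counting, with stated times of 5 min and 1 min; a higher number here means a weaker inhibitor, a lower number a stronger inhibitor. Compound 1 `O=c1[nH]nc(C[S+]([O-])C(c2ccccc2)c2ccccc2)s1` gives 38100 nM, compound 2 `CC(C)c1nnsc1C[S+]([O-])C(c1ccccc1)c1ccccc1` gives 69100 nM, and compound 3 `Cc1noc(C[S+]([O-])C(c2ccccc2)c2ccccc2)n1` gives 56700 nM. Compound 3 sits second highest of the three, nearest to compound 2 and furthest from compound 1, with every gap inside the scatter. The step to compound 4 `[O-][S+](Cc1csc(Br)c1)C(c1ccccc1)c1ccccc1` is 5-bromothiophen-3-yl in place of 3-methyl-1,2,4-oxadiazol-5-yl on a saturated chain carbon bound to a sulfur. Two earlier swaps at the same place bear on it: a 1.5-fold higher number from compound 1 to compound 3 (0.17 log units; within the scatter) and a 1.2-fold lower number from compound 2 to compound 3 (0.09 log units; within the scatter), neither beyond the scatter. Exchanging one five-membered aromatic ring for another at this position has so far left this assay unmoved, so no step beyond the scatter is expected for compound 4, a 1.0-fold lower number from compound 3 to compound 4 (0.01 log units; within the scatter). Compound 4 is estimated at 55000 nM, within a range of 20000 nM to 150000 nM.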

Compound 4, half-maximal inhibitory concentration: 16600 nM
Compound 4: the middle estimate sits 3.3-fold (0.52 log units) above what was measured; measured number outside the range, below it.
By their numbers in this assay, from the lowest: compound 4; then compounds 1, 3 and 2 (each within the scatter of the next).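

In this assay, the place on a saturated chain carbon bound to a sulfur proves sensitive to the ring it carries, with steps beyond the scatter (a 3.4-fold lower number from compound 3 to compound 4 (0.53 log units; beyond the scatter)) and (a 4.2-fold lower number from compound 2 to compound 4 (0.62 log units; beyond the scatter)) and (a 2.3-fold lower number from compound 1 to compound 4 (0.36 log units; beyond the scatter)). Compound 4 is thus the strongest inhibitor of the four, and its 5-bromothiophen-3-yl is the only group shown with one ring hetero atom. Nothing measured accounts for this shift. Going by these compounds, whether the step belongs to the bromine or to the thiophene ring stays open, as both enter together. On these data alone, how a chlorine on that ring, an amine or a longer chain would read at this place is also open.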